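The source may hold more compounds than are shown below. What is called first, only, known or untested is meant among the compounds shown, and "the series" means these compounds.

Measured in an ADME assay on microsomes from liver (Homo sapiens) for metabolic stability, read by LC-MS, with a stated time of 10 min; on this read-out higher numbers stand for a more stable compound and lower numbers for a less stable compound:
- Compound 1 `CN(C[C@H]1Cc2c(cccc2N2CCN(C3COC3)CC2)CN1)[C@H]1CCCc2cccnc21`: 83.1%
- Compound 2 `CN(C[C@H]1Cc2c(cccc2N2CCN(C3CC3)CC2)CN1)[C@H]1CCCc2cccnc21`: 15.5%

Among the compounds with values here, of these two, compound 2 stands lowest, at 15.5%, and compound 1 is its only neighbour. The next step leads to compound 3 `CN(C[C@H]1Cc2c(cccc2N2CCNC(C)(C)C2)CN1)[C@H]1CCCc2cccnc21`, which is not yet measured. It carries 3,3-dimethylpiperazin-1-yl in place of 4-cyclopropylpiperazin-1-yl on an aromatic carbon. Within the data shown here, one measured step bears on this: a number 67.6 percentage points lower from compound 1 to compound 2 (beyond the scatter), where cyclopropyl took the place of oxetan-3-yl on an amine nitrogen in a ring. That step is large and beyond the scatter. Among the measured compounds shown here, compound 3 no longer has the cyclopropyl, but no measured compound carries 3,3-dimethylpiperazin-1-yl, so the guide is a rough one. The expected step is a number 39.5 percentage points higher from compound 2 to compound 3 (beyond the scatter), upward and beyond the scatter, though probably smaller than the measured one. For compound 3 the estimate is 55%, with an expected range from 30% to 82%.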

Compound 3, percent of the compound remaining: 100%
Estimate against measurement, compound 3: 45 percentage points below; measured number above the stated range.
By their numbers in this assay, from the lowest: compound 2; then compound 1; then compound 3.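

Measured in this assay the swap of 4-cyclopropylpiperazin-1-yl for 3,3-dimethylpiperazin-1-yl on this aromatic carbon gives a number 84.5 percentage points higher from compound 2 to compound 3 (beyond the scatter) and shows that the position can carry a high number without an oxetan-3-yl group. The new group also outdoes 4-(oxetan-3-yl)piperazin-1-yl, with a number 16.9 percentage points higher from compound 1 to compound 3 (beyond the scatter) as a modest step, so the oxetan-3-yl compound no longer marks the top of this short series. Nothing available explains either step. The change adds two methyl groups and leaves the ring amine with its hydrogen, and the compounds shown do not separate these two features. From the compounds shown here alone, a plain piperazin-1-yl without the methyl groups, or a morpholin-4-yl group at the same carbon, would bear on that question, and its result here remains unknown.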